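Swapping Nitro for Hydroxymethyl at the Assay Limit

This account rests on a few compounds, and the source may have more. Where it says the series, first, only, none or still open, it means among the compounds named here.

- Compound 1 `Nc1n[nH]c(N)c1/N=N/c1ccccc1[N+](=O)[O-]` gives > 100000 nM as a limit.
- Compound 2 `Nc1n[nH]c(N)c1/N=N/c1ccc([N+](=O)[O-])cc1` gives > 100000 nM as a limit.

Both readings come from a functional assay on G-361 cells (Homo sapiens) for antiproliferative activity (a higher number here means a weaker inhibitor, a lower number a stronger inhibitor), and are limits of the test, not exact numbers. Compound 1 stands at the limit of > 100000 nM in this assay, at which 2 of the 2 values shown sit. Its true potency is therefore unknown, and no order can be drawn between compound 1 and compound 2.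

The next molecule, compound 3 `Nc1n[nH]c(N)c1/N=N/c1ccccc1CO`, keeps the shared core but carries hydroxymethyl in place of nitro on an aromatic carbon. Within the data shown here, no measured pair here differs in one place, so the data offer no step from which to judge this change. The expectation starts from compound 1, which reads > 100000 nM, a limit. A small gain in potency is expected, and another reading at the limit would be no surprise. The expected change is an at least 1.4-fold lower number from compound 1 to compound 3 (0.15 log units; that floor lies within the scatter) in this assay. The estimated value for compound 3 is 70000 nM, with an expected range from 20000 nM to 150000 nM.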

Compound 3, half-maximal inhibitory concentration: > 100000 nM
Compound 3: no number, only a limit; the forecaster's own chance of this, stated with the estimate: 60%; at least 1.4-fold (0.15 log units) between middle value and limit.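

Compound 3 gives only a limit, as compound 1 does, so no step can be read between compound 1 and compound 3 for hydroxymethyl in place of nitro: the limit of > 100000 nM in this assay, at which 3 of the 3 values shown sit.

How strong each of these compounds truly is in this assay, and whether this swap changes potency at all, stays open.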